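Configuration step from compound 1 to compound 4

A few compounds are considered here, and "the series" means these few. Any claim that something is new, unique, unknown or untested is made for them only; others in the source may bear on it.

In a functional assay on DU-145 cells (Homo sapiens) for cytotoxicity, read by MTT assay (on this read-out higher numbers stand for weaker inhibition and lower numbers for stronger inhibition), compound 1 (`COC(=O)C[C@@H]1C[C@@H](O)[C@H](C)[C@H](c2ccccc2)N1`) reads 6300 nM and sits at the stronger end of the three numbers, level with compound 3 (`COC(=O)C[C@H]1C[C@H](O)[C@@H](C)[C@@H](c2ccc(OC)cc2)N1`) at 6500 nM within the scatter. Compound 2 (`COC(=O)C[C@H]1C[C@@H](O)[C@@H](C)[C@@H](c2ccc(C(C)C)cc2)N1`) stands well apart on the weak side at 110000 nM in this series. Compound 4 (`COC(=O)C[C@H]1C[C@@H](O)[C@H](C)[C@@H](c2ccccc2)N1`) is still unmeasured. It differs from compound 1 by the two compounds have the same atoms and bonds and differ only in configuration as drawn: 2 of 4 stereo elements differ; a stereocentre at a saturated ring carbon is drawn S in compound 1 and R in compound 4; a stereocentre at a saturated ring carbon is drawn R in compound 1 and S in compound 4 with a stereocentre at a saturated ring carbon drawn S in compound 1 and R in compound 4, and another drawn R in compound 1 and S in compound 4. Among the compounds with values here, no measured pair isolates configuration, so the expectation is loose. A modest move toward weaker inhibition in this assay is expected, an estimated 1.7-fold higher number from compound 1 to compound 4 (0.24 log units; within the scatter) at the centre of a wide range. Compound 4 is estimated at 11000 nM (range 3500 nM to 40000 nM).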

Compound 4, half-maximal inhibitory concentration: 64100 nM
Estimate against measurement, compound 4: 5.8-fold (0.77 log units) below; measured number above the stated range.
By their numbers in this assay, from the lowest: compounds 1 and 3 (each within the scatter of the next); then compounds 4 and 2 (each within the scatter of the next).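

In this assay the series now has its first readable step, a 10-fold higher number from compound 1 to compound 4 (1.01 log units; beyond the scatter), and it is large. Inverting two stereocentres at saturated ring carbons together weakens inhibition this far with no atom or bond changed. The step is read as an effect of configuration alone because of one fact: the fact that compounds 1 and 4 differ only in the configuration as drawn.

Which of the two stereocentres carries the step stays open, since both change together. Also open, on these data alone, is whether a carboxylic acid in place of the ester would show the same dependence on configuration.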